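A methoxy group on the phenyl of compound 3

This account rests on a few compounds, and the source may have more. Where it says the series, first, only, none or still open, it means among the compounds named here.

Compound 3 `NS(=O)(=O)c1ccc(-c2oc3ccccc3c(=O)c2-c2ccccc2)cc1` carries a free sulfonamide on one phenyl and an unsubstituted phenyl on the other side of the shared core. In an assay on isolated protein for inhibition of prostaglandin G/H synthase 1 (Mus musculus), tested at 10 ug/mL (on this read-out lower numbers stand for less inhibition and higher numbers for more inhibition at the one concentration tested (going by the name of the read-out)), compound 3 gives 61%, the lower of the two numbers shown, though the gap to its nearest neighbour is only a number 6 percentage points lower from compound 1 to compound 3 (within the scatter), so compound 1 `NS(=O)(=O)c1ccc(-c2oc3ccccc3c(=O)c2-c2ccc(F)cc2)cc1`, which gives 67%, stands within the scatter of it. Compound 2 `CS(=O)(=O)c1ccc(-c2oc3ccccc3c(=O)c2-c2ccc(F)cc2)cc1`, with methyl in place of amino on the sulfonyl sulfur, reports only a limit of the assay, < 8%. That change amounts to a number at least 59 percentage points lower from compound 1 to compound 2 (beyond the scatter), and the measurement sits at the limit of < 8% in this assay, at which 1 of the 3 values shown sits.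

Compound 4 `COc1ccc(-c2c(-c3ccc(S(N)(=O)=O)cc3)oc3ccccc3c2=O)cc1` differs from compound 3 by methoxy in place of hydrogen on an aromatic carbon. The measured step that bears on this is the one at the same aromatic carbon, a number 6 percentage points lower from compound 1 to compound 3 (within the scatter), where fluoro and hydrogen gave numbers within the scatter of each other. The large step of a number at least 59 percentage points lower from compound 1 to compound 2 (beyond the scatter) concerns the sulfonyl group and does not touch this position, so it offers no guidance here. On that basis no step beyond the scatter is expected, and compound 4 is estimated at 60%, between 40% and 78%. The expected move is a number 1 percentage points lower from compound 3 to compound 4 (within the scatter).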

Compound 4, a percentage reported as inhibition, at one concentration (the size of the read-out at that concentration, not a potency): 84%
The estimate for compound 4 lay 24 percentage points below the measured number, outside the stated range (above it).
By their numbers in this assay, from the lowest: compounds 3 and 1 (each within the scatter of the next); then compound 4. At a limit, below all of these: compound 2.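

The aromatic carbon para to a large group is not indifferent in this assay, although the swap of fluoro for hydrogen there had moved the number only within the scatter. Methoxy in place of hydrogen gives a number 23 percentage points higher from compound 3 to compound 4 (beyond the scatter) and methoxy in place of fluoro gives a number 17 percentage points higher from compound 1 to compound 4 (beyond the scatter), so the change from phenyl to 4-methoxyphenyl is the first at this carbon to move the number beyond the scatter, and compound 4 stands above both compound 3 and compound 1. Nothing measured in this set accounts for the rise with methoxy.

The compounds shown leave open whether an ethoxy group, a hydroxyl or a methyl on this same carbon would give a number like that of compound 4, or whether the rise belongs to methoxy alone. They also leave open whether methoxy at this carbon would change anything when methyl stands in place of amino on the sulfonyl sulfur, as it does in compound 2.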